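A few compounds are considered here, and "the series" means these few. Any claim that something is new, unique, unknown or untested is made for them only; others in the source may bear on it.

Working notes on the shared core of compound 2 `Cn1cc(-c2cc(NS(C)(=O)=O)ccc2Oc2ccc(Br)cc2)n2cncc2c1=O`, varied at the sulfonamide and at the ring borne on the oxygen. In a functional assay on HL-60 cells (Homo sapiens) for antiproliferative activity, read by MTT assay (a lower number here means a stronger inhibitor, a higher number a weaker inhibitor), compound 2 gives 230 nM, the lowest of the three numbers in hand. Within the data shown here, compound 1 `Cn1cc(-c2cc(NS(C)(=O)=O)ccc2Oc2cccc(Br)c2)n2cncc2c1=O` gives 450 nM; the step of a 2.0-fold lower number from compound 1 to compound 2 (0.29 log units; within the scatter) is the only single-point change measured so far. Among the measured compounds shown here, compound 3 `CCS(=O)(=O)Nc1ccc(Oc2cccc(-c3c(C)noc3C)c2)c(-c2cn(C)c(=O)c3cncn23)c1`, which carries an ethylsulfonamide together with a 3,5-dimethyl-1,2-oxazol-4-yl group, gives 530 nM; it differs from compound 2 in two places, so no step is computed, and its value lies close to those of compound 1 and compound 2. Compound 4 `Cc1noc(C)c1-c1ccc(Oc2ccc(NS(C)(=O)=O)cc2-c2cn(C)c(=O)c3cncn23)cc1` differs from compound 2 by 3,5-dimethyl-1,2-oxazol-4-yl in place of bromo on an aromatic carbon. For the measured compounds named here, no measured step isolates this exchange; the one step in hand, a change of ring position, stayed within the scatter, and compound 3 shows that the oxazole group is compatible with a number in the same range. The expected step is therefore none beyond the scatter, a 1.3-fold higher number from compound 2 to compound 4 (0.12 log units; within the scatter). Compound 4 is estimated at 300 nM, with a range of 100 nM to 900 nM.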

Compound 4, half-maximal inhibitory concentration: 1120 nM
Estimate against measurement, compound 4: 3.7-fold (0.57 log units) below; measured number outside the range, above it.
By their numbers in this assay, from the lowest: compounds 2, 1 and 3 (each within the scatter of the next, the first and the last beyond it); then compound 4.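

In this assay, among these compounds, the exchange of bromo for 3,5-dimethyl-1,2-oxazol-4-yl on the aromatic carbon para to a large group gives a 4.9-fold higher number from compound 2 to compound 4 (0.69 log units; beyond the scatter) and is the first single-point step beyond the scatter. Among the compounds shown here, this position on the ring borne on the oxygen therefore responds to the group it carries, a response that the one earlier step, the shift of the bromine, did not reveal. Nothing in hand explains the size of this step.

Compound 3 carries the same oxazole group but differs from compound 4 in more than one place, so the contributions of its ring position and its ethylsulfonamide cannot be separated. Going by these compounds, it remains open whether a chloro, a methoxy, an amine or a carboxylic acid at this position would keep the number near that of compound 2.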